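A Piperidin-1-yl in Place of Morpholin-4-yl

The compounds below may be only part of what the source reports. "The series", "measured", "known", "first", "only" and "open" are said of these compounds alone.

Compound 1: `O=c1c(Cl)c(CSC(=S)N2CCOCC2)oc2ccccc12`, 4500 nM
Compound 2: `CC(C)N(C(=S)SCc1coc2cc(Cl)ccc2c1=O)C(C)C`, > 25000 nM
Compound 3: `O=c1c(Cl)c(CSC(=S)N2CCCCC2)oc2ccccc12`, not yet measured

Of the compounds shown here, two have so far been tested in a functional assay on HeLa cells (Homo sapiens) for antiproliferative activity, read by MTT assay, with a stated time of 72 h; a lower number here means a stronger inhibitor, a higher number a weaker inhibitor. Within the data shown here, compound 1 gives 4500 nM, the only actual number in this set. Compound 2 gives > 25000 nM, which is a limit of the assay rather than a number. As the evidence puts it, (the limit of > 25000 nM in this assay, at which 1 of the 2 values shown sits). Among the measured compounds shown here, compound 1 therefore stands alone as the one compound with a measurable result, and no step between measured compounds can be drawn.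

Compound 3 is the next compound to be measured. It differs from compound 1 at a single place: piperidin-1-yl in place of morpholin-4-yl on a thiocarbonyl carbon. Since no comparable change has been measured here, there is no direct guide to its effect. Compound 3 is expected to stay close to compound 1, with a step of a 1.3-fold lower number from compound 1 to compound 3 (0.11 log units; within the scatter), which lies within the usual scatter of repeated measurements. The estimate for compound 3 in this assay is 3500 nM, with a range from 1200 nM to 12000 nM.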

Compound 3, half-maximal inhibitory concentration: 9800 nM
For compound 3 the middle estimate is 2.8-fold (0.45 log units) below the measured one, and the stated range covers the measured number.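

In this assay, putting piperidin-1-yl in place of morpholin-4-yl on a thiocarbonyl carbon gives a 2.2-fold higher number from compound 1 to compound 3 (0.34 log units; beyond the scatter). Among these compounds, this is the first step in the set that can be read between two measured compounds, and it shows that this position responds to a swap of a single ring atom, the oxygen of morpholin-4-yl for a carbon, while compound 3 still gives a real number of 9800 nM rather than a limit, so the activity is weakened but not lost. Nothing at hand explains why the number rises with this change.

One step cannot tell whether the oxygen itself matters or whether other ring atoms in that spot would serve equally well. Still open, from the compounds shown here alone, is how the shared core would behave with thiomorpholin-4-yl, which carries sulfur where morpholin-4-yl carries oxygen, with 4-methylpiperazin-1-yl, which carries a second nitrogen, or with a small open-chain amine such as dimethylamino on the same thiocarbonyl carbon.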